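Amide aryl exchange in the shared core: compound 4

This account rests on a few compounds, and the source may have more. Where it says the series, first, only, none or still open, it means among the compounds named here.

Compound 1 `O=C(Nc1ccccc1)c1c(O)c2cccnc2n(-c2ccccc2)c1=O` serves as the reference point. In a functional assay on the whole organism for inhibition, with Rattus norvegicus as the target, read by cytopathic effect and paw edema, at a dose of 100 mg/kg by the oral route (on this read-out higher numbers stand for more inhibition at the one dose given (going by the name of the read-out) and lower numbers for less inhibition), compound 1 gives -15%, the lowest of the three numbers recorded so far. Compound 2 `COc1ccc(NC(=O)c2c(O)c3cccnc3n(-c3ccccc3)c2=O)cc1` gives -1.9%, and compound 3 `COc1ccccc1NC(=O)c1c(O)c2cccnc2n(-c2ccccc2)c1=O` gives -10.1%. Both measured steps that leave compound 1 put methoxy in place of hydrogen on an aromatic carbon of the anilino part: a number 13.1 percentage points higher from compound 1 to compound 2 (beyond the scatter), whereas a number 4.9 percentage points higher from compound 1 to compound 3 (within the scatter). Between the two methoxy compounds, a number 8.2 percentage points lower from compound 2 to compound 3 (within the scatter).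

Compound 4 `Cc1cnccc1NC(=O)c1c(O)c2cccnc2n(-c2ccccc2)c1=O` is not yet measured. Relative to compound 1 the change is 3-methylpyridin-4-yl in place of phenyl on an amide-type nitrogen. Among the compounds with values here, no measured step exchanges the whole phenyl for another ring; the nearest analogy is substitution on that phenyl, which moved the read-out up modestly in one case and stayed within the scatter in the other. A small upward movement or none beyond the scatter is therefore expected, a number 10 percentage points higher from compound 1 to compound 4 (within the scatter). For compound 4 the estimate is -5%, with a range from -25% to 15%.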

Compound 4, a percentage reported as inhibition, in the whole organism at one dose (the size of the read-out at that dose, not a potency): 8.8%
For compound 4 the middle estimate is 13.8 percentage points below the measured one, and the stated range covers the measured number.
By their numbers in this assay, from the lowest: compounds 1, 3 and 2 (each within the scatter of the next, the first and the last beyond it); then compound 4.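

In this assay the exchange of phenyl for 3-methylpyridin-4-yl on the amide-type nitrogen gives a number 23.8 percentage points higher from compound 1 to compound 4 (beyond the scatter) and so shows that this position accepts a ring other than phenyl with a gain on this read-out. The new ring also stands clear of both methoxy compounds, with a number 18.9 percentage points higher from compound 3 to compound 4 (beyond the scatter) and with a number 10.7 percentage points higher from compound 2 to compound 4 (beyond the scatter) as well. Within the data shown here, compound 4 is therefore the highest of the four, and the only one with a positive number, so replacing the ring has done more here than adding methoxy to the phenyl. Nothing at hand explains this rise.

Compound 4 carries the ring nitrogen and the methyl together, so their shares stay unresolved without a plain pyridinyl or a methylphenyl on the same nitrogen. Going by these compounds, how the read-out responds to an amine or a carboxylic acid on the new ring also remains open.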